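A few compounds are considered here, and "the series" means these few. Any claim that something is new, unique, unknown or untested is made for them only; others in the source may bear on it.

Series notes. Compound 1 `CC(C)N(Cc1cccc(OCCCCCC(=O)O)c1)C(=O)c1ccc(-c2cccc(Oc3ccccc3)c2)cc1` carries the free acid chain; compound 2 `CCOC(=O)CCCCCOc1cccc(CN(C(=O)c2ccc(-c3cccc(-c4ccccc4)c3)cc2)C(C)C)c1`, compound 3 `CCOC(=O)CCCCCOc1cccc(CN(C(=O)c2ccc(-c3cccc(C(C)=O)c3)cc2)C(C)C)c1` and compound 4 `CCOC(=O)CCCCCOc1cccc(CN(C(=O)c2ccc(-c3cccc(Oc4ccccc4)c3)cc2)C(C)C)c1` carry the ethyl ester. In an ADME assay on HepG2 cells (Homo sapiens) for cytotoxicity, read by CellTiter-Glo and resazurin assay, with a stated time of 72 h (a lower number here means that less compound is needed, a higher number that more compound is needed for the effect), compound 1 gives > 18700 nM, a limit of the assay rather than a number. In this assay compound 2 gives > 26000 nM, likewise a limit. In this assay compound 3 gives > 26000 nM, again a limit. The step that the two limits leave unreadable from compound 2 to compound 3 is therefore unreadable. Compound 3 thus stands at a limit shared with one further value, with no readable position among the three. The change to compound 4 is phenoxy in place of acetyl on an aromatic carbon. Bearing on it are the limit of > 18700 nM in this assay, at which 1 of the 3 values shown sits, and (the limit of > 26000 nM in this assay, at which 2 of the 3 values shown sit); no measured step has a readable size, so no direction follows from them. Compound 4 is expected at 26000 nM (range 15000 nM to 60000 nM), a step of a number no higher from compound 3 to compound 4 (the limit leaves the size open) estimated to stay within the scatter, most probably again a limit.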

Compound 4, half-maximal effective concentration: > 26000 nM
Compound 4 was reported as a limit (the forecaster's own chance of this, stated with the estimate: 85%); the middle value sits exactly at the limit.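

Within the data shown here, compound 1, compound 2, compound 3 and compound 4 all stand as limits in this assay, so no step among them can be read. Left open is whether phenyl, acetyl, phenoxy, or the free acid against the ethyl ester, makes any difference to the read-out.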